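A few compounds are considered here, and "the series" means these few. Any claim that something is new, unique, unknown or untested is made for them only; others in the source may bear on it.

Measured compounds:
compound 1 `O=[N+]([O-])c1cc2c(OCCC3CCCCN3)c(-c3ccccc3Cl)c(O)nc2cc1Cl`: 360 nM
compound 2 `Cc1cc(C)cc(-c2c(O)nc3cc(Cl)c(NC(=O)Nc4ncccn4)cc3c2OCCC2CCCCN2)c1`: 6 nM

In a functional assay on cells (Pituitary gland cell) for antagonist activity at Gonadotropin-releasing hormone receptor (Rattus norvegicus) (a lower number here means a stronger inhibitor, a higher number a weaker inhibitor), compound 1 gives 360 nM, the higher of the two numbers recorded here. For the measured compounds named here, compound 2 gives 6 nM in this assay, a far lower number and well beyond the scatter; the two compounds differ in several places at once, so no single step connects them. Compound 3 `O=[N+]([O-])c1cc2c(OCCC3CCCCN3)c(-c3cc(Cl)cc(Cl)c3)c(O)nc2cc1Cl` is not yet measured. It differs from compound 1 in one place: 3,5-dichlorophenyl in place of 2-chlorophenyl on an aromatic carbon. Going by the values given here, no measured pair shows how this change acts on the shared core. With only that to go on, the step of a 2.4-fold lower number from compound 1 to compound 3 (0.38 log units; beyond the scatter) is expected to be small, at most a modest fall in the number and possibly nothing beyond the scatter. Compound 3 is therefore estimated at 150 nM, within a range from 40 nM to 600 nM.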

Compound 3, half-maximal inhibitory concentration: 24 nM
Beside the measured number, compound 3's estimate is 6.3-fold (0.80 log units) above it, outside the stated range (below it).
By their numbers in this assay, from the lowest: compound 2; then compound 3; then compound 1.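

In this assay, 3,5-dichlorophenyl in place of 2-chlorophenyl gives a 15-fold lower number from compound 1 to compound 3 (1.18 log units; beyond the scatter), the first measured sign that the number responds to a change at this position. The aromatic carbon ortho to both the 2-(piperidin-2-yl)ethoxy group and the hydroxy group is thus a place where the chlorine pattern of the phenyl group matters greatly on the core of compound 1. No measurement at hand offers an explanation for the size of this step.

Going by these compounds, whether the step comes from losing the 2-chlorophenyl group or from gaining the 3,5-dichlorophenyl group remains open, and a 3-chlorophenyl or an unsubstituted phenyl group on the same core would help to separate the two. Also open, on these data alone, is whether a bromine or a methoxy group in place of these chlorines would give a similar number.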